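The compounds below may be only part of what the source reports. "The series", "measured", "known", "first", "only" and "open" are said of these compounds alone.

Measured so far in this series:
compound 1 `CCCCC#Cc1c(C)[nH]c2ccc(OC)cc2c1=O`: 1020 10^-6 cm/s
compound 2 `CCCCC#Cc1c(C)[nH]c2ccc(Cl)cc2c1=O`: 171 10^-6 cm/s
compound 3 `COc1ccc2c(=O)c(Cc3ccccc3)c(C)[nH]c2c1`: 200 10^-6 cm/s

In an ADME assay for permeability, using PAMPA, at pH 4 (on this read-out lower numbers stand for lower permeability and higher numbers for higher permeability), compound 1 gives 1020 10^-6 cm/s and compound 2 gives 171 10^-6 cm/s. The change between them is chloro in place of methoxy on an aromatic carbon, and it produced a 6.0-fold lower number from compound 1 to compound 2 (0.78 log units; beyond the scatter). Compound 3 gives 200 10^-6 cm/s in this assay; the difference between the core of compound 1 and the core of compound 3 is not broken down here.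

Compound 4 `Cc1[nH]c2cc(Cl)ccc2c(=O)c1Cc1ccccc1` is not yet measured. It differs from compound 3 by chloro in place of methoxy on an aromatic carbon, the same change as from compound 1 to compound 2, made on the same kind of place. For compound 4 the expected step in this assay is a 4.4-fold lower number from compound 3 to compound 4 (0.65 log units; beyond the scatter), set beside the earlier 6.0-fold lower number from compound 1 to compound 2 (0.78 log units; beyond the scatter). This expectation rests on compound 3 at 200 10^-6 cm/s as the starting point and on that single earlier step. Compound 4 is therefore estimated at 45 10^-6 cm/s, expected between 18 10^-6 cm/s and 130 10^-6 cm/s.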

Compound 4, apparent permeability: 341 10^-6 cm/s
Compound 4: middle estimate off by 7.6-fold (0.88 log units), on the low side; measured number outside the range, above it.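

In this assay, chloro in place of methoxy on an aromatic carbon gives a 1.7-fold higher number from compound 3 to compound 4 (0.23 log units; within the scatter), so on this core the change is not resolved from the scatter. The step therefore does not carry over unchanged from one core to the other: the same change on two cores in this assay, a 6.0-fold lower number (0.78 log units; beyond the scatter) from compound 1 to compound 2 and a 1.7-fold higher number (0.23 log units; within the scatter) from compound 3 to compound 4, 10-fold (1.01 log units) apart, beyond the scatter of two such steps. Going by these compounds alone, with only two pairs, this shows that the outcome of the change depends on the core, but it does not show which part of the core is responsible or how the change would behave on a third core.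

Open, as far as these compounds go, is whether a fluoro, a nitrile or an amine at the same aromatic carbon would also follow the core. Also open, from the compounds shown here alone, is whether a longer chain in place of the benzyl group would shift the step.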